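Removing the Nitro Group: What Compound 4 Should Tolerate

The source may hold more compounds than are shown below. What is called first, only, known or untested is meant among the compounds shown, and "the series" means these compounds.

Of the compounds shown here, three built on the same core have been tested in an ADME assay on HEL cells (Homo sapiens) for cytotoxicity, with a stated time of 3 days; a lower number here means that less compound is tolerated, a higher number that more compound is tolerated. Compound 1 `CC(C)CC1(Cc2ccccc2)OS(=O)(=O)C=C1OCc1ccccc1` gives >= 80000 nM in this assay, which is a limit of the measurement rather than a number. Compound 2 `CCC1(Cc2ccccc2)OS(=O)(=O)C=C1NCc1ccccc1` likewise reaches the limit, >= 80000 nM. Compound 3 `CCC1(Cc2ccccc2)OS(=O)(=O)C=C1OCc1ccc([N+](=O)[O-])cc1` also stops at the limit, >= 80000 nM. Compound 3 therefore stands exactly where the other two stand, at the limit of >= 80000 nM in this assay, at which 3 of the 3 values shown sit. Compound 4 `CCC1(Cc2ccccc2)OS(=O)(=O)C=C1OCc1ccccc1` has not yet been measured; it differs from compound 3 by hydrogen in place of nitro on an aromatic carbon. Among the compounds with values here, since no measured pair offers a readable step, the expected step of a number no higher from compound 3 to compound 4 (the limit leaves the size open) is none beyond the scatter. Compound 4 is accordingly expected to give 80000 nM, within a range of 40000 nM to 160000 nM.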

Compound 4, minimum cytotoxic concentration: >= 50000 nM
Compound 4 gave a limit, no number; the forecaster's own chance of this, stated with the estimate: 85%; the middle value lies beyond the limit too.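

Within the data shown here, compound 4, like compound 1, compound 2 and compound 3, gives only a limit in this assay, and no step between them can be read. The compounds shown leave open the concentration at which any of them would harm these cells.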